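Swapping the benzyl aryl group on a bis(trifluoromethyl) sulfonamide

The source may hold more compounds than are shown below. What is called first, only, known or untested is meant among the compounds shown, and "the series" means these compounds.

Compound 1 `CC(C)(C)c1ccc(CNCCCNS(=O)(=O)c2cc(C(F)(F)F)cc(C(F)(F)F)c2)cc1`: 2100 nM
Compound 2 `O=S(=O)(NCCCNCc1ccc(Cl)c(C(F)(F)F)c1)c1cc(C(F)(F)F)cc(C(F)(F)F)c1`: 3500 nM
Compound 3 `O=S(=O)(NCCCNCc1ccc(Br)cc1)c1cc(C(F)(F)F)cc(C(F)(F)F)c1`: 1900 nM

All three compounds share the same core, a bis(trifluoromethyl)phenyl sulfonamide linked through a three-carbon chain to an amine that carries a benzyl group; they differ only in the substituents on that benzyl ring. In a functional assay on MCF7 cells (Homo sapiens) for inhibition, read by MTT assay, with a stated time of 72 h (on this read-out higher numbers stand for weaker inhibition of growth and lower numbers for stronger inhibition of growth), compound 3 gives 1900 nM, the lowest of the three numbers, yet its distance to the others is small: the step from compound 1 to compound 3 is a 1.1-fold lower number from compound 1 to compound 3 (0.04 log units; within the scatter) and the step from compound 2 to compound 3 is a 1.8-fold lower number from compound 2 to compound 3 (0.27 log units; within the scatter). Compound 1 and compound 2 are likewise close, a 1.7-fold higher number from compound 1 to compound 2 (0.22 log units; within the scatter). The three compounds thus read as one group within the usual scatter.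

Compound 4 `COc1ccccc1CNCCCNS(=O)(=O)c1cc(C(F)(F)F)cc(C(F)(F)F)c1` has not been measured. Its change from compound 3 is 2-methoxyphenyl in place of 4-bromophenyl on a saturated chain carbon bound to an amine nitrogen. Among the compounds with values here, no measured step involves a methoxy group or this ring position, so the earlier steps bear on it only indirectly: every change of the benzyl aryl group so far stayed within the scatter, whether it added or removed bulk, halogen or trifluoromethyl. The expected step from compound 3 to compound 4 in this assay is therefore small, a 1.3-fold higher number from compound 3 to compound 4 (0.10 log units; within the scatter), in no particular direction. Compound 4 is estimated at 2400 nM, with a likely range from 1000 nM to 5800 nM.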

Compound 4, concentration for 50% growth inhibition: 2600 nM
Estimate against measurement, compound 4: 1.1-fold (0.03 log units) below; low and high end bracket the measured number.
By their numbers in this assay, from the lowest: compounds 3, 1, 4 and 2 (each within the scatter of the next).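

Within the data shown here, compound 4 brings the first methoxy group to this ring, and 2-methoxyphenyl counts one hydrogen-bond acceptor where 4-bromophenyl counts none, yet in this assay the change from the bromo compound is small, a 1.4-fold higher number from compound 3 to compound 4 (0.14 log units; within the scatter). The comparisons with the other two compounds are equally small, a 1.3-fold lower number from compound 2 to compound 4 (0.13 log units; within the scatter) and a 1.2-fold higher number from compound 1 to compound 4 (0.09 log units; within the scatter), so all four compounds now lie within the scatter of one another, and the range of aryl groups that leave the number essentially unchanged at this position, on a saturated chain carbon bound to an amine nitrogen, extends to a methoxy-bearing ring. No measurement is available that would explain this insensitivity to the aryl group.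

From the compounds shown here alone, it remains open whether the picture would hold for a benzyl ring bearing a more strongly different group, such as a carboxylic acid or a dimethylamino group, or for a pyridine ring in place of the benzene ring. These four compounds also say nothing about changes elsewhere in the shared core, such as a longer chain between the sulfonamide and the amine.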